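The source may hold more compounds than are shown below. What is called first, only, known or untested is meant among the compounds shown, and "the series" means these compounds.

Measured in a functional assay on the whole organism for inhibition, with Mus musculus as the target; a higher number here means that more compound is needed for the effect, a lower number that less compound is needed:
- compound 1 `CC(C)C1(C)CCOC1=O`: 198 mg/kg
- compound 2 `CC1CCSC1=O`: 91 mg/kg

Compound 2, at 91 mg/kg, holds the lower of the two numbers, and the gap to compound 1 lies beyond the usual scatter. The next compound is compound 3 `CCC1CCSC1=O`, which differs from compound 2 by methyl in place of hydrogen on a saturated chain carbon bound to a saturated ring carbon, or methyl to ethyl when read one bond further out. Among the compounds with values here, no measured pair isolates this change. With compound 2 at 91 mg/kg as the only anchor, a small step toward a lower number is expected in this assay, and it may stay within the scatter. The estimated change is a 1.3-fold lower number from compound 2 to compound 3 (0.11 log units; within the scatter). For compound 3 the expected value is 70 mg/kg, with an estimated range of 35 mg/kg to 140 mg/kg.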

Compound 3, dose for half-maximal effect: 414 mg/kg
The estimate for compound 3 lay 5.9-fold (0.77 log units) below the measured number, and the stated range ends below it.
By their numbers in this assay, from the lowest: compound 2; then compound 1; then compound 3.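

Within the data shown here, until now, the series held no pair differing in one place. In this assay, methyl in place of hydrogen on a saturated chain carbon bound to a saturated ring carbon now gives a 4.5-fold higher number from compound 2 to compound 3 (0.66 log units; beyond the scatter) and so costs dose beyond the scatter. A single added carbon at this place, read one bond further out as methyl to ethyl, is thus enough to change the dose needed, and no measurement at hand accounts for the size of this step.

As far as these compounds go, whether a longer chain such as propyl, or an amine or a carboxylic acid carried at this place, would follow the same direction remains open. One step also leaves open whether the same change reads alike on the core of compound 1.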